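Swapping a sulfamoyl for a trifluoromethyl on the hydrazide

A few compounds are considered here, and "the series" means these few. Any claim that something is new, unique, unknown or untested is made for them only; others in the source may bear on it.

Going by the values given here, compound 2 `CC(=O)Nc1ccc(S(=O)(=O)NNc2ccc(S(N)(=O)=O)cc2)cc1` stands at the weaker end of the two numbers so far: in an assay for inhibition of Indoleamine 2,3-dioxygenase 1 (Homo sapiens), read by spectrophotometry, with stated times of 1 h and 4 h (on this read-out lower numbers stand for stronger inhibition and higher numbers for weaker inhibition), compound 2 gives 2480 nM, while the unsubstituted parent, compound 1 `CC(=O)Nc1ccc(S(=O)(=O)NNc2ccccc2)cc1`, gives 71 nM. Among the compounds with values here, the one step already measured, a 35-fold higher number from compound 1 to compound 2 (1.54 log units; beyond the scatter), shows that placing a sulfamoyl on the outer ring costs a great deal. Compound 3 `CC(=O)Nc1ccc(S(=O)(=O)NNc2ccc(C(F)(F)F)cc2)cc1` differs from compound 2 by trifluoromethyl in place of sulfamoyl on an aromatic carbon. Within the data shown here, no measured step covers a trifluoromethyl at this position, so the only guide is that removing the sulfamoyl undoes the change that hurt compound 2, while the new group is not a hydrogen. The expectation is therefore that this assay falls back toward compound 1, and the step of a 6.2-fold lower number from compound 2 to compound 3 (0.79 log units; beyond the scatter) is expected to be a marked drop. For compound 3 the estimated value is 400 nM, within a range from 100 nM to 2500 nM.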

Compound 3, half-maximal inhibitory concentration: 1610 nM
The estimate for compound 3 lay 4.0-fold (0.60 log units) below the measured number; the measured number falls inside the stated range.
By their numbers in this assay, from the lowest: compound 1; then compounds 3 and 2 (each within the scatter of the next).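

In this assay the exchange of groups gives a 1.5-fold lower number from compound 2 to compound 3 (0.19 log units; within the scatter) so sulfamoyl and trifluoromethyl cannot be told apart at this position. Against the unsubstituted parent, trifluoromethyl gives a 23-fold higher number from compound 1 to compound 3 (1.36 log units; beyond the scatter) so the large loss is not confined to sulfamoyl: both groups, despite having no atom type in common and differing in their hydrogen-bond donors and acceptors, give numbers well above that of compound 1. No measured evidence is available to explain this result.

Only hydrogen, sulfamoyl and trifluoromethyl are shown at this position, so these compounds cannot say whether every replacement for hydrogen costs this much. A fluorine, a methyl, an amine or a carboxylic acid in the same place could stay close to compound 1 or fall with compound 2 and compound 3.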